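The source may hold more compounds than are shown below. What is called first, only, known or untested is meant among the compounds shown, and "the series" means these compounds.

Compound 2, `C=C1CC[C@@H]2[C@](C)(CO)[C@H](O)CC[C@@]2(C)[C@@H]1/C=C/C1=C/C(=C/c2ccc(F)cc2)OC1=O`, gives 19.5% in a functional assay on 5637 cells (Homo sapiens), read by wound healing assay, with a stated time of 48 h, tested at 5 uM; a lower number here means less inhibition, a higher number more inhibition at the concentration tested (going by the name of the read-out). For the measured compounds named here, on the numbers so far it sits highest of the two compounds measured, though its one neighbour, compound 1, `C=C1CC[C@@H]2[C@](C)(CO)[C@H](O)CC[C@@]2(C)[C@@H]1/C=C/C1=C/C(=C/c2ccc(OC)cc2)OC1=O`, gives 17.9%, and the step of a number 1.6 percentage points higher from compound 1 to compound 2 (within the scatter) does not rise above the scatter, so no order between the two can be claimed. Compound 3, `C=C1CC[C@@H]2[C@](C)(CO)[C@H](O)CC[C@@]2(C)[C@@H]1/C=C/C1=C/C(=C/c2ccc(Br)cc2)OC1=O`, is the compound not yet measured; it differs from compound 2 by bromo in place of fluoro on an aromatic carbon. Going by the values given here, only one measured step touches the same place on the shared core: the exchange of methoxy for fluoro, with its size given by a number 1.6 percentage points higher from compound 1 to compound 2 (within the scatter), and it changed nothing beyond the scatter. Compound 3 is therefore expected to lie close to compound 2, with an expected step of a number 0.5 percentage points higher from compound 2 to compound 3 (within the scatter) and no direction that can be defended. The estimate for compound 3 is 20%, within 6% to 34%.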

Compound 3, a percentage reported as inhibition, at one concentration (the size of the read-out at that concentration, not a potency): 27.9%
Compound 3: middle estimate off by 7.9 percentage points, on the low side, within the range that was stated.
By their numbers in this assay, from the lowest: compounds 1, 2 and 3 (each within the scatter of the next).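

With bromo, this position on the aromatic ring has now carried three different groups, and the widest spread so far still does not clear the scatter. In this assay, the change from 4-fluorophenyl to 4-bromophenyl gives a number 8.4 percentage points higher from compound 2 to compound 3 (within the scatter), and bromo in place of methoxy gives a number 10 percentage points higher from compound 1 to compound 3 (within the scatter); both steps are larger than the earlier exchange of methoxy for fluoro, but neither supports an order among the three groups. Nothing shown here accounts for the size of these steps. As far as these compounds go, it remains open whether an amine, a carboxylic acid or a longer chain at this place would move the number beyond the scatter. From the compounds shown here alone, it is also open whether iodo or chloro would fall in with the three groups seen so far.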